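A few compounds are considered here, and "the series" means these few. Any claim that something is new, unique, unknown or untested is made for them only; others in the source may bear on it.

In a functional assay on KB cells (Homo sapiens) for antiproliferative activity, read by MTT assay, with a stated time of 48 h (a higher number here means a weaker inhibitor, a lower number a stronger inhibitor), compound 1 (`Cn1cc(C2=C(c3nn(CCn4ccnc4)c4ncccc34)C(=O)N(c3ccccc3)C2=O)c2ccccc21`) gives > 100000 nM, which is a limit and not a number. Compound 3 (`Cn1cc(C2=C(c3nn(CCn4ccnc4)c4ncccc34)C(=O)NC2=O)c2ccccc21`) gives > 100000 nM, also a limit. Compound 2 (`Cn1cc(C2=C(c3nn(CCCN4CCCCC4)c4ncccc34)C(=O)NC2=O)c2ccccc21`) gives a number, 98000 nM. The series is thus marked by the limit of > 100000 nM in this assay, at which 2 of the 3 values shown sit.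

Compound 4 (`Cn1cc(C2=C(c3nn(CCCCn4ccnc4)c4ncccc34)C(=O)N(c3ccccc3)C2=O)c2ccccc21`) differs from compound 1 by 2-(1H-imidazol-1-yl)ethyl in place of 1H-imidazol-1-yl on a saturated chain carbon, two bonds along the chain from an aromatic nitrogen, with 2-(1H-imidazol-1-yl)ethyl in place of 1H-imidazol-1-yl on a saturated chain carbon, two bonds along the chain from an aromatic nitrogen.

The nearest guide is a change at this same place, an at least 1.0-fold higher number from compound 2 to compound 3 (0.00 log units; that floor lies within the scatter). The other measured step, a step that the two limits leave unreadable from compound 1 to compound 3, concerns the amide-type nitrogen and gives no size. No shift beyond the scatter is therefore expected in this assay, in either direction. The expected step is an at least 1.1-fold lower number from compound 1 to compound 4 (0.04 log units; that floor lies within the scatter). The estimate for compound 4 is 90000 nM, with an expected range of 25000 nM to 150000 nM.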

Compound 4, half-maximal inhibitory concentration: 47300 nM
Compound 4: middle estimate off by 1.9-fold (0.28 log units), on the high side, within the range that was stated.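

In this assay, among the compounds shown here, the change from a 2-(1H-imidazol-1-yl)ethyl to a 4-(1H-imidazol-1-yl)butyl chain gives the first step that reads as beyond the scatter: an at least 2.1-fold lower number from compound 1 to compound 4 (0.32 log units; beyond the scatter). Compound 1 gives > 100000 nM, which is a limit. That limit still marks the series: the limit of > 100000 nM in this assay, at which 2 of the 4 values shown sit.

The compounds shown leave open whether a chain longer than 4-(1H-imidazol-1-yl)butyl would lower the number further. They also leave open whether the same lengthening holds with hydrogen in place of phenyl on the amide-type nitrogen, or with a morpholine at the chain end in place of the imidazole.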